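Working notes: solubility across two cores, lactam methylation

The source may hold more compounds than are shown below. What is called first, only, known or untested is meant among the compounds shown, and "the series" means these compounds.

Measured compounds:
compound 1 `CN(c1ccn(C)n1)c1cnc(NCc2c(F)ccc3c2CCO3)c2cn[nH]c(=O)c12` — 12000 nM
compound 2 `Cn1cc(-c2cnc(NCc3c(F)ccc4c3CCO4)c3cn[nH]c(=O)c23)cn1` — 1000 nM
compound 3 `O=C1CCCN1c1cnc(NCc2c(F)ccc3c2CCO3)n2cnnc12` — 640000 nM

In a physicochemical assay for solubility, read by LC-MS, in phosphate buffer, with a stated time of 24 h, at pH 7.4 (on this read-out higher numbers stand for higher solubility and lower numbers for lower solubility), compound 3 gives the highest of the three numbers. Its nearest neighbour is compound 1, and the gap between the two values is beyond the scatter; compound 2 lies further away still, so compound 3 stands clearly apart on this read-out.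

Going by the values given here, the only step measured in one place is a 12-fold lower number from compound 1 to compound 2 (1.08 log units; beyond the scatter). That change sits on an aromatic carbon of a different core and concerns a replacement of one whole group by another, so it says nothing direct about what follows.

Compound 4 `C[C@H]1CC(=O)N(c2cnc(NCc3c(F)ccc4c3CCO4)n3cnnc23)C1` differs from compound 3 by methyl in place of hydrogen on a saturated ring carbon. Among the compounds with values here, no measured pair carries a methyl onto a saturated ring carbon, so no step bears on this change, and the expectation rests on its small size alone. The step from compound 3 to compound 4 is expected to be small, most likely within the scatter and if anything a lower number: a 1.6-fold lower number from compound 3 to compound 4 (0.20 log units; within the scatter). For compound 4 the estimate is 400000 nM, with a range from 150000 nM to 1000000 nM.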

Compound 4, solubility: 200000 nM
Compound 4: the middle estimate sits 2.0-fold (0.30 log units) above what was measured; low and high end bracket the measured number.
By their numbers in this assay, from the lowest: compound 2; then compound 1; then compound 4; then compound 3.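

In this assay, the change from 2-oxopyrrolidin-1-yl to 4-methyl-2-oxopyrrolidin-1-yl gives a 3.2-fold lower number from compound 3 to compound 4 (0.51 log units; beyond the scatter) and so lies beyond the scatter. Going by these compounds alone, this is the first read on a saturated ring carbon two ring bonds from the ring nitrogen, and it shows that the number responds at this position to a change of a single heavy atom. No measurement on hand bears on the reason for this step.

Still open, as far as these compounds go, is whether the methyl of opposite configuration, or the hydrogen replaced by an ethyl, a hydroxyl or an amine at the same place, would move the number further or in the other direction. One step also leaves unresolved whether the same methyl would have a comparable effect on another core.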